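Sulfonyl substituent change from compound 1 to compound 4

This account rests on a few compounds, and the source may have more. Where it says the series, first, only, none or still open, it means among the compounds named here.

Compound 1 `CS(=O)(=O)N[C@@H](CNC(=O)c1ccc2c(c1)C(=O)N(CCC1CCNCC1)C2)C(=O)O` gives 14 nM in a functional assay for inhibition, with Homo sapiens as the target; a lower number here means a stronger inhibitor, a higher number a weaker inhibitor. Among the three measured compounds it stands second highest; its nearest neighbour is compound 2 `CCCCNC(=O)N[C@@H](CNC(=O)c1ccc2c(c1)C(=O)N(CCC1CCNCC1)C2)C(=O)O`, which gives 16 nM, and the step of a 1.1-fold higher number from compound 1 to compound 2 (0.06 log units; within the scatter) stays within the scatter. The furthest is compound 3 `O=C(NC[C@H](NS(=O)(=O)Cc1ccccc1)C(=O)O)c1ccc2c(c1)C(=O)N(CCC1CCNCC1)C2`, which gives 4 nM; the step of a 3.5-fold lower number from compound 1 to compound 3 (0.54 log units; beyond the scatter) lies beyond the scatter, as does a 4.0-fold lower number from compound 2 to compound 3 (0.60 log units; beyond the scatter).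

Compound 4 `O=C(O)c1ccc(S(=O)(=O)N[C@@H](CNC(=O)c2ccc3c(c2)C(=O)N(CCC2CCNCC2)C3)C(=O)O)cc1` differs from compound 1 in one place: 4-carboxyphenyl in place of methyl on a sulfonyl sulfur. The measured step that bears most on this is a 3.5-fold lower number from compound 1 to compound 3 (0.54 log units; beyond the scatter), where an aromatic ring entered on the chain carbon bound to the sulfonyl sulfur. Within the data shown here, in compound 4 the ring sits on the sulfonyl sulfur itself and carries a carboxy group, a combination that no measured compound shows. Among the measured compounds shown here, a modest lowering of the number in this assay is therefore expected, kept smaller than a 3.5-fold lower number from compound 1 to compound 3 (0.54 log units; beyond the scatter) since the direct aromatic attachment has no measured precedent. For compound 4 the estimate in this assay is 8 nM, with a range from 3 nM to 25 nM. This estimate for compound 4 means an expected step of a 1.8-fold lower number from compound 1 to compound 4 (0.24 log units; within the scatter).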

Compound 4, half-maximal inhibitory concentration: 7 nM
For compound 4 the middle estimate is 1.1-fold (0.06 log units) above the measured one, and the stated range covers the measured number.
By their numbers in this assay, from the lowest: compounds 3, 4, 1 and 2 (each within the scatter of the next, the first and the last beyond it).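

In this assay, 4-carboxyphenyl on the sulfonyl sulfur, the first aromatic ring attached directly there, is accommodated: a 2.0-fold lower number from compound 1 to compound 4 (0.30 log units; within the scatter) and a 1.8-fold higher number from compound 3 to compound 4 (0.24 log units; within the scatter) both stay within the scatter, so at this position the group cannot be told apart from methyl or from benzyl, even though compound 1 and compound 3 are separated by a step beyond the scatter. Among these compounds, the one step from compound 4 that does pass the scatter is a 2.3-fold lower number from compound 2 to compound 4 (0.36 log units; beyond the scatter), a modest gain for (4-carboxyphenyl)sulfonyl over butylcarbamoyl on the amine nitrogen, and it sets no general preference for sulfonyl groups, as compound 1 goes against it with a 1.1-fold higher number from compound 1 to compound 2 (0.06 log units; within the scatter). Nothing on hand explains why these steps take the size they do.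

The compounds shown leave open whether the aromatic ring or its carboxylic acid accounts for the value of compound 4. A plain phenyl on the sulfonyl sulfur would separate the two, and a butyl chain there would show how far a longer alkyl group departs from methyl.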